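Removing the acetyl: cytotoxicity notes toward compound 4

The source may hold more compounds than are shown below. What is called first, only, known or untested is meant among the compounds shown, and "the series" means these compounds.

Compound 2 `CC(=O)Nc1ccc2c(c1)/C(=C(/Nc1ccc(CN3CCCCC3)cc1)c1ccccc1)C(=O)N2` is one of three members of the series measured for cytotoxicity. In an ADME assay on HepG2 cells (Homo sapiens) for cytotoxicity, read by MTT assay, with a stated time of 48 h (on this read-out lower numbers stand for higher toxicity in this test and higher numbers for lower toxicity in this test), compound 2 reaches only the limit of the test, > 6 uM, a limit and not a read number. Compound 3 `CCS(=O)(=O)Nc1ccc2c(c1)/C(=C(\C)Nc1ccc(CN3CCCCC3)cc1)C(=O)N2` likewise gives a limit in this assay, > 6 uM. For the measured compounds named here, compound 1 `CCS(=O)(=O)Nc1ccc2c(c1)/C(=C/Nc1ccc(CN3CCCCC3)cc1)C(=O)N2` is the only member with a read number: in this assay compound 1 gives 5 uM. This places compound 2 at the limit of > 6 uM in this assay, at which 2 of the 3 values shown sit, so no distinct position among the numbers can be given for it.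

Compound 4 `Nc1ccc2c(c1)/C(=C(/Nc1ccc(CN3CCCCC3)cc1)c1ccccc1)C(=O)N2` is not yet measured. It differs from compound 2 in one place: hydrogen in place of acetyl on a nitrogen on an aromatic ring, which cut one bond further out reads acetamido to amino. Going by the values given here, no step between two measured compounds covers this change, so nothing measured speaks for a shift beyond the scatter in either direction. The expected step is a number no higher from compound 2 to compound 4 (the limit leaves the size open), none beyond the scatter. Compound 4 is therefore expected to give about 6 uM in this assay, within a range from 3 uM to 15 uM, with a fair chance that only a limit is again reported.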

Compound 4, half-maximal toxic concentration: > 6 uM
Compound 4 was reported as a limit; the forecaster's own chance of this, stated with the estimate: 55%; the middle value sits exactly at the limit.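

In this assay compound 4, like compound 2, is reported only as a limit, so no step from acetamido to amino can be read between the two compounds: the limit of > 6 uM in this assay, at which 3 of the 4 values shown sit.

The compounds shown leave open where compound 2 and compound 4 would fall as read numbers, and whether acetamido to amino changes the value at all.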